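Methylsulfanyl in place of selenium on the benzylamine core

A few compounds are considered here, and "the series" means these few. Any claim that something is new, unique, unknown or untested is made for them only; others in the source may bear on it.

Compound 2 `COc1ccc(CNc2nc([SeH])nc3ccccc23)cc1` is the weakest-scoring of the two compounds with a numerical reading: in a functional assay on MCF7 cells (Homo sapiens) for cytotoxicity, read by MTT assay, with a stated time of 72 h (a higher number here means a weaker inhibitor of growth, a lower number a stronger inhibitor of growth), compound 2 gives 94000 nM, which is the highest of the numbers shown, and its nearest neighbour compound 1 `CSc1ccc(CNc2nc(SC)nc3ncccc23)cc1` sits far lower, beyond the scatter, since in this assay compound 1 gives 4370 nM. Compound 3 `CSc1nc(NCCCCCO)c2ccccc2n1` is reported only as a limit of the assay: in this assay compound 3 gives > 100000 nM. That limit is noted as the limit of > 100000 nM in this assay, at which 1 of the 3 values shown sits.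

Compound 4 `COc1ccc(CNc2nc(SC)nc3ccccc23)cc1` has not been measured. It differs from compound 2 by a group of 2 heavy atoms (1 carbon, 1 sulfur; no ring) in place of one selenium atom, on an aromatic carbon. For the measured compounds named here, no pair of measured compounds differs in one place, so no measured step describes this change directly. Compound 1 carries methylsulfanyl at the same kind of carbon and reads far below compound 2, so a decrease in the number is expected for compound 4, the expected step being a 9.4-fold lower number from compound 2 to compound 4 (0.97 log units; beyond the scatter). The estimate for compound 4 in this assay is 10000 nM, within a range from 2000 nM to 50000 nM; the width reflects that compound 1 also differs from compound 4 in its core and its benzyl substituent.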

Compound 4, concentration for total growth inhibition: 85100 nM
The estimate for compound 4 lay 8.5-fold (0.93 log units) below the measured number, outside the stated range (above it).
By their numbers in this assay, from the lowest: compound 1; then compounds 4 and 2 (each within the scatter of the next). At a limit, above all of these: compound 3.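

In this assay, replacing the selenium atom with methylsulfanyl on the aromatic carbon between two ring nitrogen atoms barely moves the reading: a 1.1-fold lower number from compound 2 to compound 4 (0.04 log units; within the scatter). For the compounds shown here, at this position, with the core and benzyl substituent of compound 2 held fixed, the two groups cannot be told apart, so methylsulfanyl at this carbon is not enough by itself to bring the number down on this core; compound 1 differs from compound 4 in more than one place, so no step between them can be read. Nothing measured in this set offers an account of why this exchange leaves the reading unmoved.

Open questions remain at this carbon and beyond it: whether an amine or a longer alkylsulfanyl chain at the same position would shift the reading of the shared core, and whether the core or the benzyl substituent goes with the value of compound 1, 4370 nM. Compound 3 stands only as a limit of the assay, not a number: the limit of > 100000 nM in this assay, at which 1 of the 4 values shown sits.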